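Swapping an oxane for a hydroxypiperidine on the sulfonyl group

This account rests on a few compounds, and the source may have more. Where it says the series, first, only, none or still open, it means among the compounds named here.

Measured compounds:
- compound 1, `O=S(=O)(c1ccccc1)c1ccc(CNS(=O)(=O)N2Cc3ccncc3C2)cc1`: > 2000 nM
- compound 2, `CCCn1cc(S(=O)(=O)c2ccc(CNC(=O)N3Cc4ccncc4C3)cc2)cn1`: 17 nM
- compound 3, `O=C(NCc1ccc(S(=O)(=O)C2CCCOC2)cc1)N1Cc2ccncc2C1`: 44 nM

In an assay on isolated protein for inhibition of Nicotinamide phosphoribosyltransferase (Homo sapiens), read by mass spectrometry, with stated times of 15 min and 30 min (a higher number here means a weaker inhibitor, a lower number a stronger inhibitor), compound 1 gives > 2000 nM, which is a limit of the assay rather than a number. Compound 2 gives 17 nM in this assay. Compound 3 gives 44 nM in this assay, the highest of the two numbers shown; the nearest number is that of compound 2, and the step of a 2.6-fold higher number from compound 2 to compound 3 (0.41 log units; beyond the scatter) is the only measured change in the group attached to the sulfonyl sulfur.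

Compound 4, `O=C(NCc1ccc(S(=O)(=O)N2CCC[C@H](O)C2)cc1)N1Cc2ccncc2C1`, is not yet measured. It differs from compound 3 by 3-hydroxypiperidin-1-yl in place of oxan-3-yl on a sulfonyl sulfur. For the measured compounds named here, the one measured step at this position, a 2.6-fold higher number from compound 2 to compound 3 (0.41 log units; beyond the scatter), was modest, and no measured pair shows what a hydroxyl or a nitrogen-linked ring does there. Compound 4 is therefore expected to sit close to compound 3, with a step of a 1.4-fold higher number from compound 3 to compound 4 (0.13 log units; within the scatter) that may not exceed the scatter. The estimate for compound 4 in this assay is 60 nM, within 20 nM to 200 nM.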

Compound 4, half-maximal inhibitory concentration: 770 nM
Beside the measured number, compound 4's estimate is 13-fold (1.11 log units) below it; the measured number lies above the stated range.
By their numbers in this assay, from the lowest: compound 2; then compound 3; then compound 4. At a limit, above all of these: compound 1.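

In this assay, for the compounds shown here, the group on the sulfonyl sulfur matters far more than the earlier pair showed: the change to 3-hydroxypiperidin-1-yl gives an 18-fold higher number from compound 3 to compound 4 (1.24 log units; beyond the scatter), whereas the only earlier step at this position was a 2.6-fold higher number from compound 2 to compound 3 (0.41 log units; beyond the scatter). The change from 1-propyl-1H-pyrazol-4-yl gives a 45-fold higher number from compound 2 to compound 4 (1.66 log units; beyond the scatter), and oxan-3-yl and 3-hydroxypiperidin-1-yl, though both six-membered non-aromatic rings, are clearly not interchangeable here. Nothing shown explains why this change costs so much.

The swap brings in the hydroxyl and the ring nitrogen on the sulfonyl sulfur together, so the compounds shown leave open which of the two goes with the loss. A plain piperidin-1-yl and a 3-methoxypiperidin-1-yl would help separate them, and the mirror-image form of the 3-hydroxypiperidin-1-yl group remains an open question too.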